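The source may report more compounds than this note shows. Statements on the series, on what has been measured and on what is new or still open speak of the compounds shown alone.

Compound 1 `CC(C)c1ccc(-c2nc3sccn3c2/C=N/OCc2ccc(Cl)c(Cl)c2)cc1` gives 590 nM in an assay on HepG2 cells for agonist activity at nuclear receptor subfamily 1 group I member 3 (Homo sapiens), read by a luciferase reporter, with a stated time of 23 h; on this read-out lower numbers stand for an effect already at smaller amounts and higher numbers for an effect only at larger amounts of compound. Compound 3 `Fc1ccc(-c2nc3sccn3c2/C=N/OCc2ccc(Cl)c(Cl)c2)cc1` gives 670 nM. Compound 2 `Clc1ccc(CO/N=C/c2c(-c3ccc(C4CCCCC4)cc3)nc3sccn23)cc1Cl` reaches only a limit of the assay, > 100000 nM.

Of the two numbers, compound 3 sits highest, yet the step of a 1.1-fold higher number from compound 1 to compound 3 (0.06 log units; within the scatter) lies within the scatter, so compound 1 and compound 3 cannot be told apart. Compound 4 `Clc1ccc(CO/N=C/c2c(-c3ccccc3)nc3sccn23)cc1Cl` differs from compound 3 by hydrogen in place of fluoro on an aromatic carbon. Two measured steps bear on this place: a 1.1-fold higher number from compound 1 to compound 3 (0.06 log units; within the scatter) was small, while an at least 160-fold higher number from compound 1 to compound 2 (2.22 log units; beyond the scatter) was very large, so only the bulky cyclohexyl has shown a clear effect there. Taking away a fluoro is a small change, and the expected step of a 1.2-fold higher number from compound 3 to compound 4 (0.08 log units; within the scatter) is therefore none beyond the scatter. Compound 4 is estimated at 800 nM, in the range 300 nM to 2500 nM.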

Compound 4, half-maximal effective concentration: 580 nM
Compound 4: the middle estimate sits 1.4-fold (0.14 log units) above what was measured, and the stated range covers the measured number.
By their numbers in this assay, from the lowest: compounds 4, 1 and 3 (each within the scatter of the next). At a limit, above all of these: compound 2.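

Taking the group off this ring carbon altogether changes little: the steps of a 1.2-fold lower number from compound 3 to compound 4 (0.06 log units; within the scatter) and a 1.0-fold lower number from compound 1 to compound 4 (0.01 log units; within the scatter) both lie within the scatter, so hydrogen, fluoro and isopropyl cannot be told apart here. Compound 2 stands at a limit of the assay, not at a number: the limit of > 100000 nM in this assay, at which 1 of the 4 values shown sits. Within the data shown here, measured against the plain phenyl, cyclohexyl remains the only group at this place with a clear effect, with an at least 170-fold lower number from compound 2 to compound 4 (2.23 log units; beyond the scatter).

Still open, going by these compounds, is how a tert-butyl, a cyclopentyl, an amine or a carboxylic acid would read at this place. The shown compounds therefore cannot say whether the effect belongs to cyclohexyl alone.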